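A few compounds are considered here, and "the series" means these few. Any claim that something is new, unique, unknown or untested is made for them only; others in the source may bear on it.

Compound 1 `N#Cc1ccc(-c2cnc3[nH]cc(-c4nnc(-c5ccc(F)cc5)o4)c(=O)c3c2)cc1`: 12.6%
Compound 2 `N#Cc1ccc(-c2cnc3[nH]cc(-c4nnc(-c5ccc(Cl)cc5)o4)c(=O)c3c2)cc1`: 17.9%
Compound 3 `CS(=O)(=O)c1ccc(-c2cnc3[nH]cc(-c4nnc(-c5cccnc5)o4)c(=O)c3c2)cc1`: 9.26%

In a functional assay on HCT-116 cells (Homo sapiens) for inhibition, read by MTT assay, with a stated time of 24 h, tested at 5 uM (a lower number here means less inhibition of growth, a higher number more inhibition of growth at the concentration tested), the three measured compounds give numbers that differ from one another by no more than the usual scatter. Compound 1 differs from compound 2 by a number 5.3 percentage points higher from compound 1 to compound 2 (within the scatter), and its number is likewise close to that of compound 3; no ordering among the three can be read from these values.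

Compound 4 `O=c1c(-c2nnc(-c3ccc(F)cc3)o2)c[nH]c2ncc(-c3ccncc3)cc12` is to be measured in this assay. It differs from compound 1 by pyridin-4-yl in place of 4-cyanophenyl on an aromatic carbon. Going by the values given here, none of the measured steps touches this position: the only measured step, a number 5.3 percentage points higher from compound 1 to compound 2 (within the scatter), concerns the halogen on the other aryl group, and compound 3 differs from compound 1 in two places at once, so its value cannot be attributed to either change. There is therefore no basis for expecting a step beyond the scatter in either direction, and the estimate simply stays near the measured numbers.

Compound 4 is accordingly expected to give 13%, with a range from 3% to 26%. This estimate corresponds to an expected step of a number 0.4 percentage points higher from compound 1 to compound 4 (within the scatter).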

Compound 4, percent growth inhibition at one concentration: 10.9%
Estimate against measurement, compound 4: 2.1 percentage points above; the measured number falls inside the stated range.
By their numbers in this assay, from the lowest: compounds 3, 4, 1 and 2 (each within the scatter of the next).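

This is the first single change shown on the aromatic carbon that carries the 4-cyanophenyl group in compound 1: in this assay, pyridin-4-yl in its place gives a number 1.7 percentage points lower from compound 1 to compound 4 (within the scatter). For this pair, therefore, the nitrile and the carbon-only ring can both be exchanged without a step beyond the scatter, although this one replacement says nothing about other groups at the same place. No measurement among the data bears on why the number holds here.

As far as these compounds go, it remains open whether a group without an aromatic ring at this place, such as a primary amine, a carboxylic acid or a morpholine, would give a step beyond the scatter. From the compounds shown here alone, it also remains open whether pyridin-4-yl would give a similar step with chloro in place of fluoro on the other aryl group.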